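The compounds below may be only part of what the source reports. "The series", "measured", "known", "first", "only" and "open" are said of these compounds alone.

Compound 3 `C#CCn1cc(C(=O)NC(CC(=O)NC2CCCCC2)c2ccccc2)c(=O)c2cc(F)c(Cl)nc21` gives 2300 nM in a functional assay on PA-1 cells (Homo sapiens) for cytotoxicity, read by MTT assay, with a stated time of 72 h; on this read-out lower numbers stand for stronger inhibition and higher numbers for weaker inhibition. Compound 1 `C#CCn1cc(C(=O)NC(CC(=O)Nc2ccccc2)c2ccccc2)c(=O)c2cc(F)c(Cl)nc21` gives 2100 nM, and compound 2 `C#CCn1cc(C(=O)NC(CC(=O)Nc2ccccn2)c2ccccc2)c(=O)c2ccc(Cl)nc21` gives 1700 nM; compound 3 sits within the usual scatter of both. Compound 4 `C#CCn1cc(C(=O)NC(CC(=O)Nc2ccccn2)c2ccccc2)c(=O)c2cc(F)c(Cl)nc21` differs from compound 3 by pyridin-2-yl in place of cyclohexyl on an amide-type nitrogen. For the measured compounds named here, one measured step bears on this place: a 1.1-fold higher number from compound 1 to compound 3 (0.04 log units; within the scatter), where an aromatic ring was swapped for cyclohexyl at the same nitrogen without effect beyond the scatter. Compound 2 already carries the pyridin-2-yl amide on a core without the fluorine, and its value and that of compound 3 lie within the scatter of each other. No step beyond the scatter is therefore expected for a 1.2-fold lower number from compound 3 to compound 4 (0.08 log units; within the scatter). Compound 4 is thus estimated at 1900 nM, with a range from 900 nM to 4000 nM.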

Compound 4, half-maximal inhibitory concentration: > 10000 nM
Compound 4: no number, only a limit; the forecaster's own chance of this, stated with the estimate: 3%; at least 5.2-fold (0.72 log units) between middle value and limit.
By their numbers in this assay, from the lowest: compounds 2, 1 and 3 (each within the scatter of the next). At a limit, above all of these: compound 4.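

Compound 4 gives no number, only a limit: the limit of > 10000 nM in this assay, at which 1 of the 4 values shown sits. With the fluoro on the core, the group on this amide nitrogen does matter: pyridin-2-yl gives an at least 4.3-fold higher number from compound 3 to compound 4 (0.63 log units; beyond the scatter) against cyclohexyl and an at least 4.7-fold higher number from compound 1 to compound 4 (0.67 log units; beyond the scatter) against phenyl. Fluoro in place of hydrogen gives an at least 5.8-fold higher number from compound 2 to compound 4 (0.76 log units; beyond the scatter), so among these compounds only the pairing of fluoro with pyridin-2-yl, found in compound 4 alone, reaches the limit.

The compounds shown do not tell why the pairing has this result. They also leave open whether pyridin-3-yl or morpholin-4-yl on this nitrogen would give a number or a limit.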